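Aryl hydrazone variation on a shared core

The source may report more compounds than this note shows. Statements on the series, on what has been measured and on what is new or still open speak of the compounds shown alone.

In a functional assay on PC-3 cells (Homo sapiens) for antiproliferative activity, read by MTT assay (on this read-out higher numbers stand for weaker inhibition and lower numbers for stronger inhibition), compound 3 `CSc1ccc(/C=N/Nc2ncc3c(n2)n(C2CCCC2)c(=O)c(=O)n3C)cc1` gives 21000 nM, the second highest of the three numbers. Compound 2 `Cn1c(=O)c(=O)n(C2CCCC2)c2nc(N/N=C/c3ccccc3F)ncc21` gives 27600 nM, and the two values lie within the scatter of each other, as the step of a 1.3-fold lower number from compound 2 to compound 3 (0.12 log units; within the scatter) shows. Compound 1 `Cn1c(=O)c(=O)n(C2CCCC2)c2nc(N/N=C/c3ccc(F)cc3Br)ncc21` gives 9250 nM, and the step of a 2.3-fold higher number from compound 1 to compound 3 (0.36 log units; beyond the scatter) is beyond the scatter.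

Compound 4 `Cn1c(=O)c(=O)n(C2CCCC2)c2nc(N/N=C/c3ccccc3Cl)ncc21` differs from compound 3 as follows: 2-chlorophenyl in place of 4-(methylsulfanyl)phenyl on a carbon with a double bond to nitrogen. Among the measured compounds shown here, two measured steps bear on this change. The step of a 1.3-fold lower number from compound 2 to compound 3 (0.12 log units; within the scatter) sets 4-(methylsulfanyl)phenyl against a phenyl carrying a single halogen, 2-fluorophenyl, and it is within the scatter. The step of a 2.3-fold higher number from compound 1 to compound 3 (0.36 log units; beyond the scatter) sets it against 2-bromo-4-fluorophenyl, a phenyl carrying two halogens, and it is modest but beyond the scatter. Compound 4 carries a single chlorine, which places it nearer to compound 2 than to compound 1 in structure, so no step beyond the scatter is expected. Compound 4 is estimated at 18000 nM, with a range of 7000 nM to 45000 nM. The expected step is a 1.2-fold lower number from compound 3 to compound 4 (0.07 log units; within the scatter).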

Compound 4, half-maximal inhibitory concentration: 16300 nM
Compound 4: the middle estimate sits 1.1-fold (0.04 log units) above what was measured, and the stated range covers the measured number.
By their numbers in this assay, from the lowest: compounds 1, 4, 3 and 2 (each within the scatter of the next, the first and the last beyond it).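

In this assay, among the compounds shown here, the single exchanges at this place stay small: 2-chlorophenyl in place of 4-(methylsulfanyl)phenyl gives (a 1.3-fold lower number from compound 3 to compound 4 (0.11 log units; within the scatter)) and chloro in place of fluoro on an aromatic carbon gives (a 1.7-fold lower number from compound 2 to compound 4 (0.23 log units; within the scatter)). New to the series, 2-chlorophenyl is also within the scatter of 2-bromo-4-fluorophenyl (a 1.8-fold higher number from compound 1 to compound 4 (0.25 log units; within the scatter)), whereas 2-fluorophenyl (a 3.0-fold higher number from compound 1 to compound 2 (0.47 log units; beyond the scatter)) and 4-(methylsulfanyl)phenyl (a 2.3-fold higher number from compound 1 to compound 3 (0.36 log units; beyond the scatter)) both lie beyond it, so a phenyl with one halogen is not in itself set apart from compound 1. No measurement is at hand that accounts for these numbers.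

Open, as far as these compounds go, is whether a carboxylic acid or an aminomethyl group on the phenyl ring would give a step beyond the scatter from compound 4. Also open, from the compounds shown here alone, is how a phenyl carrying chlorine together with a second halogen compares with compound 1.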